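A few compounds are considered here, and "the series" means these few. Any claim that something is new, unique, unknown or untested is made for them only; others in the source may bear on it.

Measured compounds:
- compound 1, `Clc1ccc(Cn2ccc3nc(-c4ccccc4)nc-3c2)cc1`, gives > 100000 nM in an ADME assay on MDBK cells (Bos taurus) for cytotoxicity; a lower number here means that less compound is tolerated, a higher number that more compound is tolerated; this is a limit of the assay, not a number.
- compound 2, `N#Cc1cccc(Cn2ccc3nc(-c4ccccc4)nc-3c2)c1`, gives > 100000 nM in this assay; this too is a limit, not a number.
- compound 3, `Clc1ccc(Cn2ccc3nc(-c4ccccc4)nc-3c2)cc1Cl`, gives 71000 nM in this assay.

Within the data shown here, compound 3 thus stands as the only compound with a real number; the other two values sit at the limit of > 100000 nM in this assay, at which 2 of the 3 values shown sit. The steps into compound 3 are an at least 1.4-fold lower number from compound 1 to compound 3 (0.14 log units; that floor lies within the scatter) and an at least 1.4-fold lower number from compound 2 to compound 3 (0.14 log units; that floor lies within the scatter), and both can only be read as floors, each lying within the scatter.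

Compound 4, `c1ccc(-c2nc3ccn(Cc4cccnc4)cc-3n2)cc1`, is still to be measured. The change from compound 3 is pyridin-3-yl in place of 3,4-dichlorophenyl on a saturated chain carbon bound to an aromatic nitrogen. It removes the 3,4-dichlorophenyl that marks compound 3 off from the two limit compounds and brings in a ring with one hetero atom. Since compound 1 and compound 2, which lack the 3,4-dichlorophenyl, both sit at the limit, and the steps into compound 3 were at most modest, the expected step of a 2.1-fold higher number from compound 3 to compound 4 (0.32 log units; beyond the scatter) in this assay is a higher number, probably back to the limit. Compound 4 is therefore estimated at 150000 nM in this assay, with a range from 60000 nM to 400000 nM.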

Compound 4, half-maximal cytotoxic concentration: > 100000 nM
Compound 4: only a limit was reported; the forecaster's own chance of this, stated with the estimate: 70%; the middle value does not contradict the limit.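

Among these compounds, at this position, on a saturated chain carbon bound to an aromatic nitrogen, a ring with a hetero atom now appears for the first time, and pyridin-3-yl in place of 3,4-dichlorophenyl gives an at least 1.4-fold higher number from compound 3 to compound 4 (0.14 log units; that floor lies within the scatter) in this assay. As that floor is all the step provides, it does not establish a real difference, and the steps to compound 4 from compound 1 and compound 2 cannot be read, as both ends of each are limits. Compound 3 therefore remains the only compound with a real number, while 4-chlorophenyl, 3-cyanophenyl and now pyridin-3-yl all end at the same ceiling: the limit of > 100000 nM in this assay, at which 3 of the 4 values shown sit.

Going by these compounds, how far compound 1, compound 2 and compound 4 lie beyond that limit stays unknown, so no order can be given among them, and it also stays unclear whether the number for compound 3 differs meaningfully from theirs. Also open, on these data alone, is whether an amine or a carboxylic acid on the ring at this position, or a longer chain between that ring and the shared core, would bring a clearly lower number in this assay.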